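This account rests on a few compounds, and the source may have more. Where it says the series, first, only, none or still open, it means among the compounds named here.

Working notes on the series, read in an ADME assay on A549 cells (Homo sapiens) for cytotoxicity, read by resazurin assay, with a stated time of 48 h; on this read-out higher numbers stand for lower toxicity in this test and lower numbers for higher toxicity in this test. Among the compounds with values here, the group on a saturated chain carbon bound to a nitrogen on an aromatic ring is the only variation so far. Compound 1 `O=C(Nc1ccc(NCC2CCCC2)cc1Cl)c1cc(Cl)ccc1O`, with cyclopentyl, gives 21500 nM. Compound 2 `O=C(Nc1ccc(NCc2ccc(O)cc2)cc1Cl)c1cc(Cl)ccc1O`, with 4-hydroxyphenyl, gives 116000 nM. Compound 3 `O=C(Nc1ccc(NCc2cccnc2Cl)cc1Cl)c1cc(Cl)ccc1O`, with 2-chloropyridin-3-yl, gives 101000 nM.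

Compound 3 thus sits in the upper pair, within the scatter of compound 2. The gap from the cyclopentyl compound is a 4.7-fold higher number from compound 1 to compound 3 (0.67 log units; beyond the scatter), and the matching step with 4-hydroxyphenyl is a 5.4-fold higher number from compound 1 to compound 2 (0.73 log units; beyond the scatter).

Compound 4 `O=C(Nc1ccc(NCc2cccc(Br)n2)cc1Cl)c1cc(Cl)ccc1O` keeps the shared core and has 6-bromopyridin-2-yl in place of 2-chloropyridin-3-yl at the same place: 6-bromopyridin-2-yl in place of 2-chloropyridin-3-yl on a saturated chain carbon bound to a nitrogen on an aromatic ring. Within the data shown here, no measured step exchanges one pyridinyl group for another, so there is no direct precedent. The nearest evidence is the exchange of one aromatic group for another, which gave a 1.1-fold lower number from compound 2 to compound 3 (0.06 log units; within the scatter). Both modest steps involve loss of cyclopentyl, which does not apply here.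

In this assay, no step beyond the scatter is therefore expected, and the estimated change is a 1.3-fold lower number from compound 3 to compound 4 (0.13 log units; within the scatter). Compound 4 is expected at 75000 nM, with an estimated range of 33000 nM to 140000 nM.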

Compound 4, half-maximal cytotoxic concentration: 92300 nM
For compound 4 the middle estimate is 1.2-fold (0.09 log units) below the measured one; low and high end bracket the measured number.
By their numbers in this assay, from the lowest: compound 1; then compounds 4, 3 and 2 (each within the scatter of the next).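

In this assay, within the data shown here, the first exchange of one pyridinyl group for another on a saturated chain carbon bound to a nitrogen on an aromatic ring, which swaps chlorine for bromine and also changes the point of attachment to the ring, gives a 1.1-fold lower number from compound 3 to compound 4 (0.04 log units; within the scatter). The 6-bromopyridin-2-yl group also stays close to the 4-hydroxyphenyl group, with a 1.3-fold lower number from compound 2 to compound 4 (0.10 log units; within the scatter), whereas a 4.3-fold higher number from compound 1 to compound 4 (0.63 log units; beyond the scatter) puts a third aromatic group clear of cyclopentyl, and no compound among these four goes against that split between compound 1 and the three aromatic groups. No measurement on these compounds accounts for either the closeness of the aromatic groups or their gap from cyclopentyl.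

Going by these compounds, the split rests on a single saturated group, so it remains open whether cyclohexyl, a piperidinyl ring or a longer alkyl chain would fall with compound 1 or with the aromatic groups. The halogen and the point of attachment change together between compound 3 and compound 4, and a pyridin-2-yl group without bromine, or a group carrying a carboxylic acid or an amine, would test how far this tolerance extends.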